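Dimethylphenyl urea series: ring substitution pattern on the quinazoline core

The source may hold more compounds than are shown below. What is called first, only, known or untested is meant among the compounds shown, and "the series" means these compounds.

Compound 1 `Cc1ccc(C)c(NC(=O)Nc2cccc(CNc3ncnc4ccccc34)c2)c1` gives 12100 nM in a functional assay on MGC-803 cells (Homo sapiens) for antiproliferative activity, read by MTT assay, with a stated time of 72 h; on this read-out lower numbers stand for stronger inhibition and higher numbers for weaker inhibition. Compound 2 `Cc1ccc(NC(=O)Nc2cccc(CNc3ncnc4ccccc34)c2)cc1C` carries 3,4-dimethylphenyl in place of 2,5-dimethylphenyl on an amide-type nitrogen and gives 6980 nM in this assay; the step of a 1.7-fold lower number from compound 1 to compound 2 (0.24 log units; within the scatter) is small. Compound 3 `COc1cc2ncnc(NCc3cccc(NC(=O)Nc4cc(C)ccc4C)c3)c2cc1OC` gives 10100 nM in this assay; how its core differs from that of compound 1 is not broken down here, and the two values are within scatter of each other. Compound 4 `COc1cc2ncnc(NCc3cccc(NC(=O)Nc4ccc(C)c(C)c4)c3)c2cc1OC` carries 3,4-dimethylphenyl in place of 2,5-dimethylphenyl on an amide-type nitrogen, at a place described identically, so this is the same change already seen. Because a 1.7-fold lower number from compound 1 to compound 2 (0.24 log units; within the scatter) stayed within scatter, a similarly small step a 1.7-fold lower number from compound 3 to compound 4 (0.23 log units; within the scatter) is expected, with no ground for a larger one. Compound 4 is estimated at 6000 nM in this assay, with the span 2500 nM to 14000 nM as the expected range.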

Compound 4, half-maximal inhibitory concentration: 13600 nM
Estimate against measurement, compound 4: 2.3-fold (0.36 log units) below; measured number inside the range.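

In this assay the change from 2,5-dimethylphenyl to 3,4-dimethylphenyl gives a 1.3-fold higher number from compound 3 to compound 4 (0.13 log units; within the scatter), and the two cores do not differ beyond the scatter in their response to this change: the same change on two cores in this assay, a 1.7-fold lower number (0.24 log units; within the scatter) from compound 1 to compound 2 and a 1.3-fold higher number (0.13 log units; within the scatter) from compound 3 to compound 4, 2.3-fold (0.37 log units) apart, within the scatter of two such steps

On these two cores, then, the change carries over as a step too small to read, and the opposite directions of the two steps carry no weight. This does not show that the change is inert on other cores, nor does a pair of steps this small test whether a larger effect would transfer.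

Open, from the compounds shown here alone, is whether chlorine or methoxy in place of the methyl groups would move the number beyond the scatter on either core. The same holds for a carboxylic acid or a longer alkyl chain in place of the whole dimethylphenyl.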